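This account rests on a few compounds, and the source may have more. Where it says the series, first, only, none or still open, it means among the compounds named here.

Compound 1, with the structure `C=C1C(=O)[C@]23C[C@@]1(F)CC[C@H]2[C@@]12C=CC(=O)[C@](C)(C(=O)O1)[C@H]2[C@@H]3C(=O)OC`, is the starting point here. In a functional assay on HT-29 cells (Homo sapiens) for cytotoxicity, read by MTT assay (a lower number here means a stronger inhibitor, a higher number a weaker inhibitor), compound 1 gives 72700 nM. Compound 2, with the structure `C=C1C(=O)[C@]23C[C@@]1(F)CC[C@H]2[C@@]12C=CC(=O)[C@](C)(C(=O)O1)[C@H]2[C@@H]3C(=O)OCc1ccccc1`, differs from compound 1 by phenyl in place of hydrogen on a saturated chain carbon bound to an oxygen next to a carbonyl group. That change gives a 1.2-fold lower number from compound 1 to compound 2 (0.09 log units; within the scatter), and in this assay compound 2 gives 59100 nM. Compound 3, with the structure `C=C1C(=O)[C@]23C[C@@]1(OCC)CC[C@H]2[C@@]12C=CC(=O)[C@](C)(C(=O)O1)[C@H]2[C@@H]3C(=O)OC`, differs from compound 1 in another place: ethoxy in place of fluoro on a saturated ring carbon. Among the compounds with values here, this change gives a 2.1-fold lower number from compound 1 to compound 3 (0.33 log units; beyond the scatter), and in this assay compound 3 gives 34100 nM, the lowest of the three numbers so far, though its gap to compound 2 stays within the scatter.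

Compound 4, with the structure `C=C1C(=O)[C@]23C[C@@]1(OCC)CC[C@H]2[C@@]12C=CC(=O)[C@](C)(C(=O)O1)[C@H]2[C@@H]3C(=O)OCc1ccccc1`, has not yet been measured. It differs from compound 3 by phenyl in place of hydrogen on a saturated chain carbon bound to an oxygen next to a carbonyl group. This is the same change that leads from compound 1 to compound 2; it occurs twice among these compounds, and the place it sits in is described in the same words both times, so it can be called the same change on a different core. The two cores differ by ethoxy in place of fluoro on a saturated ring carbon.

Within the data shown here, because the first instance of this change gave only a 1.2-fold lower number from compound 1 to compound 2 (0.09 log units; within the scatter), a step within the scatter, the expected step from compound 3 to compound 4 in this assay is a 1.2-fold lower number from compound 3 to compound 4 (0.09 log units; within the scatter), about as small. On that basis compound 4 is expected to give about 28000 nM in this assay, most likely between 12000 nM and 65000 nM.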

Compound 4, half-maximal inhibitory concentration: 23300 nM
Compound 4: the middle estimate sits 1.2-fold (0.08 log units) above what was measured; low and high end bracket the measured number.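

In this assay, going from methoxycarbonyl to benzyloxycarbonyl on the core that carries ethoxy gives a 1.5-fold lower number from compound 3 to compound 4 (0.17 log units; within the scatter), so this change stays small on both cores and the two steps agree: the same change on two cores in this assay, a 1.2-fold lower number (0.09 log units; within the scatter) from compound 1 to compound 2 and a 1.5-fold lower number (0.17 log units; within the scatter) from compound 3 to compound 4, 1.2-fold (0.08 log units) apart, within the scatter of two such steps

The other change also carries over, as ethoxy in place of fluoro gives a 2.5-fold lower number from compound 2 to compound 4 (0.40 log units; beyond the scatter), a modest step that matches its earlier counterpart on the core with methoxycarbonyl: the same change on two cores in this assay, a 2.1-fold lower number (0.33 log units; beyond the scatter) from compound 1 to compound 3 and a 2.5-fold lower number (0.40 log units; beyond the scatter) from compound 2 to compound 4, 1.2-fold (0.08 log units) apart, within the scatter of two such steps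

These agreements show that, across these four compounds, each change has about the same size whichever form the other place takes, but they do not explain why, and two cores are too few to show that the same would hold on any other core.

The compounds shown leave open what other groups would do on the saturated ring carbon that carries fluoro or ethoxy, such as an amine or a longer chain like butoxy, and what a carboxylic acid would do in place of the methoxycarbonyl group. They also leave open whether the same steps would appear in cell types other than the one tested here.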